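Compound 4 against the shorter side-chain data

The compounds below may be only part of what the source reports. "The series", "measured", "known", "first", "only" and "open" are said of these compounds alone.

compound 1 `NCCCCN(C[C@H]1Cc2ncccc2CN1)[C@H]1CCCc2cccnc21` in an ADME assay on microsomes from liver (Mus musculus) for metabolic stability, using NADPH, with a stated time of 10 min (a lower number here means that less of the compound is left, a higher number that more of the compound is left), gives 86%
compound 2 `NCCCCN(C[C@@H]1Cc2nccnc2CN1)[C@H]1CCCc2cccnc21` gives 73%
compound 3 `NC/C=C\CN(C[C@H]1Cc2ncccc2CN1)[C@H]1CCCc2cccnc21` gives 37%

Compound 1 holds the highest of these three numbers, and compound 2 and compound 3 both lie lower, beyond the scatter. The change to compound 4 `NC(=O)NC/C=C/CN(C[C@H]1Cc2ncccc2CN1)[C@H]1CCCc2cccnc21` is a group of 7 heavy atoms (4 carbon, 2 nitrogen, 1 oxygen; no ring) in place of a group of 4 heavy atoms (3 carbon, 1 nitrogen; no ring), on a saturated chain carbon bound to an amine nitrogen and leaves the core of compound 1 as it is. Compound 2 carries the same 3-aminopropyl as compound 1 and does not bear on this change. Within the data shown here, the one measured step at this place puts 3-aminoprop-1-en-1-yl in place of 3-aminopropyl and covers only part of the change. Among the measured compounds shown here, no measured compound carries the entering group. That step is a number 49 percentage points lower from compound 1 to compound 3 (beyond the scatter) and a large step down is therefore expected in this assay for compound 4, with a wide range around it. Compound 4 is estimated at 45% within an expected range from 20% to 72% as its ends. The expected change is a number 41 percentage points lower from compound 1 to compound 4 (beyond the scatter) and remains an estimate until measured.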

Compound 4, percent of the compound remaining: 19%
Compound 4: the middle estimate sits 26 percentage points above what was measured; measured number below the stated range.
By their numbers in this assay, from the lowest: compound 4; then compound 3; then compound 2; then compound 1.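

In this assay, among these compounds, the place on a saturated chain carbon bound to an amine nitrogen proves more sensitive than the earlier compounds showed, with a fall of a number 67 percentage points lower from compound 1 to compound 4 (beyond the scatter) exceeding the fall of a number 49 percentage points lower from compound 1 to compound 3 (beyond the scatter). Going further from the unsaturated chain of compound 3 to the larger group of compound 4 recovers none of the loss and instead gives a number 18 percentage points lower from compound 3 to compound 4 (beyond the scatter). No measurement bearing on the cause of these falls is available here.

In compound 4 the chain double bond and the new chain end arrive together, so their shares in the fall remain unseparated, and compound 3 and compound 4 also differ in the geometry of that double bond. Going by these compounds, a saturated chain ending in a urea, a hydroxyl or a carboxylic acid remains open at this place.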